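Working notes: benzyloxy in place of methyl on compound 2

A few compounds are considered here, and "the series" means these few. Any claim that something is new, unique, unknown or untested is made for them only; others in the source may bear on it.

- compound 1 `O=C(/C=C(O)/C=C/c1ccc(OCc2ccccc2)cc1)/C=C/c1ccc(OCc2ccccc2)cc1`: 3.6 10^-6 cm/s
- compound 2 `COc1cc(/C=C/C(O)=C/C(=O)/C=C/c2ccc(C)cc2)ccc1O`: 8.2 10^-6 cm/s

Within the data shown here, in an ADME assay for permeability, using PAMPA (on this read-out higher numbers stand for higher permeability and lower numbers for lower permeability), compound 2 gives 8.2 10^-6 cm/s, the higher of the two numbers so far. Compound 1 gives 3.6 10^-6 cm/s, and this gap lies beyond the scatter.

The next compound is compound 3 `COc1cc(/C=C/C(O)=C/C(=O)/C=C/c2ccc(OCc3ccccc3)cc2)ccc1O`. It follows from compound 2 by one change: benzyloxy in place of methyl on an aromatic carbon, para to a large group (benzyloxy in place of methyl on an aromatic carbon).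

Among the measured compounds shown here, no measured pair shows this change in isolation, so the expectation rests on two values alone. Compound 1 also carries benzyloxy and reads lower in this assay at 3.6 10^-6 cm/s, so a decrease is the more likely direction. With so little data, this remains a weak basis.

The expected 1.5-fold lower number from compound 2 to compound 3 (0.17 log units; within the scatter) is a modest decrease that may not exceed the scatter.

For compound 3 the estimated value is 5.5 10^-6 cm/s, with an expected range of 2.5 10^-6 cm/s to 11 10^-6 cm/s.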

Compound 3, apparent permeability: 7.7 10^-6 cm/s
Compound 3: the middle estimate sits 1.4-fold (0.15 log units) below what was measured, and the stated range covers the measured number.
By their numbers in this assay, from the lowest: compound 1; then compounds 3 and 2 (each within the scatter of the next).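

In this assay, among these compounds, the one isolated step at this place, benzyloxy in place of methyl on an aromatic carbon, para to a large group, is a 1.1-fold lower number from compound 2 to compound 3 (0.03 log units; within the scatter). The read-out at this position therefore stays within the scatter when methyl, with 1 heavy atom, gives way to benzyloxy, with 8 heavy atoms, one six-membered aromatic ring of carbon only and 1 hydrogen-bond acceptor, so benzyloxy here does not by itself reproduce the lower number of compound 1, 3.6 10^-6 cm/s. No measurement at hand offers an explanation for this result.

On these data alone, whether this tolerance extends to other groups at the same place, such as an amine, a carboxylic acid or a longer alkyl chain, remains open. Among the compounds shown here, also open is what separates compound 1 from compound 3 elsewhere on the core, as no single-change step isolates that difference.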